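Ethyl on the saturated ring carbon, mouse microsome clearance

The source may report more compounds than this note shows. Statements on the series, on what has been measured and on what is new or still open speak of the compounds shown alone.

Measured so far in an ADME assay on microsomes from liver (Mus musculus) for metabolic stability, read by LC-MS, using NADPH, with stated times of 10 min and 30 min; a lower number here means slower removal, a higher number faster removal of the compound:
compound 1, `O=C1c2ccc(Cl)cc2CN1c1cccnc1`, gives 76.5 mL/min/kg.
compound 2, `CCC1c2cc(Cl)ccc2C(=O)N1c1cccnc1`, gives 65.9 mL/min/kg.
compound 3, `CC(=O)N[C@@H]1CCCc2c1cncc2N1Cc2cc(Cl)ccc2C1=O`, gives only a limit of this assay, < 20.2 mL/min/kg; that is the limit of < 20.2 mL/min/kg in this assay, at which 1 of the 3 values shown sits.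

From compound 1 to compound 2 the change is ethyl in place of hydrogen on a saturated ring carbon. The step in this assay is a 1.2-fold lower number from compound 1 to compound 2 (0.06 log units; within the scatter).

Compound 4, `CC[C@H]1c2cc(Cl)ccc2C(=O)N1c1cncc2c1CCC[C@H]2NC(C)=O`, is not yet measured. Against compound 3 it carries the same kind of change, (ethyl in place of hydrogen on a saturated ring carbon). The places agree except that in compound 1 the ring atom bears a pyridin-3-yl group (6 heavy atoms), while in compound 3 it bears a large group. How the core of compound 1 and the core of compound 3 differ is not broken down here.

Because compound 3 sits at the limit of < 20.2 mL/min/kg in this assay, at which 1 of the 3 values shown sits, and the earlier ethyl step came out as a 1.2-fold lower number from compound 1 to compound 2 (0.06 log units; within the scatter), compound 4 is expected to stay near that limit, an estimated step that the limit leaves unreadable from compound 3 to compound 4. The estimate for compound 4 in this assay is 15 mL/min/kg, expected between 5 mL/min/kg and 32 mL/min/kg, with a fair chance that this assay again reports only a limit.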

Compound 4, clearance: < 20.2 mL/min/kg
Compound 4 ended at the assay's limit; the forecaster's own chance of this, stated with the estimate: 60%; the middle value does not contradict the limit.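

In this assay compound 3 and compound 4 both end at a limit, so the ethyl step between them cannot be read: the limit of < 20.2 mL/min/kg in this assay, at which 2 of the 4 values shown sit.

The compounds shown leave open what clearance either compound actually has, and whether ethyl in place of hydrogen on a saturated ring carbon changes clearance at all on the core of compound 3.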